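Ethyl in Place of Methoxy on the Shared Core

The source may hold more compounds than are shown below. What is called first, only, known or untested is meant among the compounds shown, and "the series" means these compounds.

Of the compounds shown here, three have been tested in a functional assay on the whole organism (strain Sprague-Dawley) for inhibition, with Rattus norvegicus as the target; on this read-out lower numbers stand for an effect already at smaller amounts and higher numbers for an effect only at larger amounts of compound. Compound 1 `FC(F)(F)c1ccc2cc(-c3nn[nH]n3)cnc2c1` gave only a limit of that assay, < 10 mg/kg, and not a number. Compound 3 `O=c1c(-c2nn[nH]n2)c[nH]c2c(Cl)c(Cl)ccc12` likewise gave a limit, > 0.156 mg/kg. For the measured compounds named here, compound 2 `COc1cccc2c(=O)c(-c3nn[nH]n3)c[nH]c12` is the one compound with a real number, 0.15 mg/kg, and so it is the only fixed point from which to set out. Compound 4 `CCc1cccc2c(=O)c(-c3nn[nH]n3)c[nH]c12` differs from compound 2 in a single place: ethyl in place of methoxy on an aromatic carbon. Going by the values given here, no measured pair shows what this swap does, so the change in this assay is expected to be small, without a clear direction, and none beyond the usual scatter. The step from compound 2 to compound 4 is thus expected as a 1.3-fold higher number from compound 2 to compound 4 (0.12 log units; within the scatter). Compound 4 is expected at 0.2 mg/kg, most likely between 0.05 mg/kg and 0.8 mg/kg.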

Compound 4, minimum effective dose: 0.312 mg/kg
Compound 4: middle estimate off by 1.6-fold (0.19 log units), on the low side; the range from low to high includes it.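

For the compounds shown here, this is the first measured step for any change at this position on the shared core: ethyl in place of methoxy on an aromatic carbon gives a 2.1-fold higher number from compound 2 to compound 4 (0.32 log units; beyond the scatter) in this assay and so costs a modest but real amount of effect. Swapping out the methoxy group thus moves the dose needed, yet compound 4 still has an effect at a dose of the same general order. Nothing in the data shown explains this shift.

Going by these compounds, what an amine or a longer chain such as propyl would do on this same aromatic carbon remains open.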